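Ortho chlorine on the benzamide of compound 2

This account rests on a few compounds, and the source may have more. Where it says the series, first, only, none or still open, it means among the compounds named here.

Compound 1 `O=C(Nc1ccc(Cl)c(-c2nnc3c(Cl)cccn23)c1)c1ccc(C(F)(F)F)cc1F`: in a functional assay on MDA-MB-231 cells (Homo sapiens) for antiproliferative activity, read by MTT assay, with stated times of 72 h and 4 h (on this read-out lower numbers stand for stronger inhibition and higher numbers for weaker inhibition), compound 1 gives > 100000 nM, a limit of the assay.
Compound 2 `O=C(Nc1ccc(Cl)c(-c2nnc3c(Cl)cccn23)c1)c1ccccc1`: in this assay compound 2 gives 58200 nM.
Compound 3 `O=C(Nc1ccc(Cl)c(-c2nnc3c(Cl)cccn23)c1)c1c(F)cccc1Cl`: in this assay compound 3 gives > 100000 nM, a limit of the assay.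

Within the data shown here, compound 2 holds the only number in this set; the other two results are limits, as the limit of > 100000 nM in this assay, at which 2 of the 3 values shown sit, records. Compound 4 `O=C(Nc1ccc(Cl)c(-c2nnc3c(Cl)cccn23)c1)c1ccccc1Cl` differs from compound 2 by chloro in place of hydrogen on an aromatic carbon, so that the phenyl on the carbonyl carbon becomes 2-chlorophenyl. Among the measured compounds shown here, the one measured step that bears on this is an at least 1.7-fold higher number from compound 2 to compound 3 (0.23 log units; that floor lies within the scatter), which also places a chloro on the phenyl of compound 2 together with a fluoro, and which ends at the limit. Compound 1, which carries a fluoro and a trifluoromethyl on that phenyl, also sits at the limit. Neither step reveals how a chloro alone acts, and the measured step itself lies within the scatter, so the direction for compound 4 is uncertain; a weakening toward the limit seems somewhat more likely than a gain. Compound 4 is therefore expected to give about 90000 nM in this assay, within 40000 nM to 200000 nM, meaning an estimated step of a 1.5-fold higher number from compound 2 to compound 4 (0.19 log units; within the scatter).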

Compound 4, half-maximal inhibitory concentration: 59900 nM
Beside the measured number, compound 4's estimate is 1.5-fold (0.18 log units) above it; low and high end bracket the measured number.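

In this assay, the 2-chlorophenyl of compound 4 allows a chloro on this ring to be read on its own against the phenyl of compound 2, and the step is a 1.0-fold higher number from compound 2 to compound 4 (0.01 log units; within the scatter). Among these compounds, at this place, ortho to a large group, chloro in place of hydrogen therefore gives no separation from hydrogen that this read-out can resolve, which the earlier compounds, all carrying a second group or ending at a limit, could not show. Taking the fluoro away from compound 3 gives an at least 1.6-fold lower number from compound 3 to compound 4 (0.22 log units; that floor lies within the scatter), so this step does not establish a role for the fluoro, and the set still holds only two numbers, the other two results being limits of the assay: the limit of > 100000 nM in this assay, at which 2 of the 4 values shown sit.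

The compounds shown leave open whether a fluoro alone on this ring, or a chloro at another place on it, would separate from compound 2, and how far compound 1 and compound 3 lie past their limits. They also leave open whether an amine or a carboxylic acid on this phenyl would move the number at all.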